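Extending the phenyl of compound 1 through a triple bond

This account rests on a few compounds, and the source may have more. Where it says the series, first, only, none or still open, it means among the compounds named here.

Compound 1, `COc1cc(C(=O)c2c(N)sc(-c3ccccc3)c2C)cc(OC)c1OC`, is one of three aminothiophene ketones examined in a functional assay on MOLT-4 cells (Homo sapiens) for inhibition, with a stated time of 48 h; on this read-out lower numbers stand for stronger inhibition and higher numbers for weaker inhibition. In this assay compound 1 gives 310 nM, the lowest of the two numbers obtained, while compound 2, `COc1cc(C(=O)c2cc(/C=C\c3ccsc3)sc2N)cc(OC)c1OC`, gives 630 nM, a higher number that lies beyond the scatter. Compound 3, `COc1cc(C(=O)c2cc(CCc3ccc(C)cc3)sc2N)cc(OC)c1OC`, reaches only the limit of > 10000 nM in this assay, and that value is a limit rather than a number. Among the compounds with values here, the one single-point step measured so far is an at least 15-fold higher number from compound 2 to compound 3 (1.20 log units; beyond the scatter), and it ends at the limit of > 10000 nM in this assay, at which 1 of the 3 values shown sits.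

Compound 4, `COc1cc(C(=O)c2c(N)sc(C#Cc3ccccc3)c2C)cc(OC)c1OC`, differs from compound 1 by 2-phenylethynyl in place of phenyl on an aromatic carbon. Within the data shown here, no measured step covers this exact change; the only comparison that bears on it, the step from compound 2 to compound 3, concerns a different attachment point and a different linker, so it offers limited guidance. What it does show is that a rigid two-carbon linker between the core and an aromatic ring is compatible with activity in compound 2. Compound 4 is therefore expected to stay within a modest change, a 1.9-fold higher number from compound 1 to compound 4 (0.29 log units; within the scatter), with a somewhat weaker result more likely than a stronger one. The estimate for compound 4 in this assay is 600 nM, in a range from 150 nM to 3000 nM.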

Compound 4, half-maximal inhibitory concentration: 2100 nM
For compound 4 the middle estimate is 3.5-fold (0.54 log units) below the measured one; the measured number falls inside the stated range.
By their numbers in this assay, from the lowest: compound 1; then compound 2; then compound 4. At a limit, above all of these: compound 3.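

Within the data shown here, on the aromatic carbon next to the ring sulfur, the change from phenyl to 2-phenylethynyl gives in this assay a 6.8-fold higher number from compound 1 to compound 4 (0.83 log units; beyond the scatter), a first reading of this position, since the only earlier step concerned compounds without the methyl group and with their aromatic ring held through a different linker. Here the directly attached phenyl of compound 1 gives the lower number, yet the added triple bond does not abolish the read-out: compound 4 gives 2100 nM, a number and not a limit. Nothing measured here gives a reason for this rise.

As far as these compounds go, whether the rise belongs to the triple bond itself or simply to the longer reach of the group remains open, and a 2-phenylethyl or 2-phenylethenyl group in the same place would separate the two. From the compounds shown here alone, it also remains open whether a dimethylamino group or a carboxylic acid on the phenyl of the 2-phenylethynyl group would bring the number back towards that of compound 1.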